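Swapping the group on the nitrogen of compound 3

The source may hold more compounds than are shown below. What is called first, only, known or untested is meant among the compounds shown, and "the series" means these compounds.

Measured in a functional assay on DU-145 cells (Homo sapiens) for inhibition, read by trypan blue exclusion, with a stated time of 72 h; on this read-out lower numbers stand for stronger inhibition and higher numbers for weaker inhibition:
Compound 1 `Cn1c(=O)c(S(=O)(=O)c2ccc(F)cc2F)cc2cnc(Nc3cccc4[nH]ccc34)nc21`: 750 nM
Compound 2 `Cn1c(=O)c(S(=O)(=O)c2ccc(F)cc2F)cc2cnc(Nc3ccccn3)nc21`: 75000 nM
Compound 3 `Cn1c(=O)c(S(=O)(=O)c2ccc(F)cc2F)cc2cnc(Nc3ccc4cccc(O)c4n3)nc21`: 5000 nM

Compound 3, at 5000 nM, sits in the middle of these values, with compound 1 lower and compound 2 higher. Compound 4 `Cn1c(=O)c(S(=O)(=O)c2ccc(F)cc2F)cc2cnc(Nc3ccc4cc[nH]c4c3)nc21` carries 1H-indol-6-yl in place of 8-hydroxyquinolin-2-yl on a nitrogen on an aromatic ring. Compound 1 holds the closest group, 1H-indol-4-yl, and two measured swaps bear on this change: a 6.7-fold higher number from compound 1 to compound 3 (0.82 log units; beyond the scatter) and a 15-fold lower number from compound 2 to compound 3 (1.18 log units; beyond the scatter). Among the compounds with values here, no measured compound shows how 1H-indol-6-yl itself behaves. Going by compound 1 at 750 nM, a modest move towards a lower number is expected in this assay. The expected step is a 3.3-fold lower number from compound 3 to compound 4 (0.52 log units; beyond the scatter). Compound 4 is estimated at 1500 nM, within a range of 350 nM to 7000 nM.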

Compound 4, half-maximal inhibitory concentration: 5000 nM
Estimate against measurement, compound 4: 3.3-fold (0.52 log units) below; the measured number falls inside the stated range.
By their numbers in this assay, from the lowest: compound 1; then compounds 3 and 4 (each within the scatter of the next); then compound 2.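

In this assay, 1H-indol-6-yl and 8-hydroxyquinolin-2-yl read alike on this nitrogen (no change at the digits printed from compound 3 to compound 4 (within the scatter)), although they differ in ring make-up. The two indole groups do not read alike: 1H-indol-6-yl loses ground against 1H-indol-4-yl (a 6.7-fold higher number from compound 1 to compound 4 (0.82 log units; beyond the scatter)), yet it still clearly beats pyridin-2-yl (a 15-fold lower number from compound 2 to compound 4 (1.18 log units; beyond the scatter)). No measurement offered here accounts for these differences.

Open, as far as these compounds go, is how 1H-indol-5-yl would read on this nitrogen. Equally open, from the compounds shown here alone, is whether a phenyl ring carrying an amine or a carboxylic acid could match 1H-indol-4-yl.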